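Hydroxycyclopropyl Amide in Place of Oxopyrrolidinyl on Shared Core

A few compounds are considered here, and "the series" means these few. Any claim that something is new, unique, unknown or untested is made for them only; others in the source may bear on it.

Compound 1, `CC1(C)Cc2c(sc(NC(=O)c3cccnc3O)c2C(N)=O)C(C)(C)O1`, gives 190 nM in an assay on cells for positive allosteric modulation of Cystic fibrosis transmembrane conductance regulator variant F508del (Homo sapiens), with stated times of 10 min and 7 s, in the presence of a further agent that is not named here; a higher number here means that more compound is needed for the effect, a lower number that less compound is needed.
Compound 2, `CC1(C)Cc2c(sc(NC(=O)C3CCNC3=O)c2C(N)=O)C(C)(C)O1`, gives 101 nM in this assay.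
Compound 3, `CC1(C)Cc2c(sc(NC(=O)C3CNC(=O)C3)c2C(N)=O)C(C)(C)O1`, gives > 10000 nM in this assay, which is a limit of the assay and not a number.

Compound 3 is the only one of the three for which this assay reports just a limit, at the limit of > 10000 nM in this assay, at which 1 of the 3 values shown sits. The steps of an at least 52-fold higher number from compound 1 to compound 3 (1.72 log units; beyond the scatter) and an at least 99-fold higher number from compound 2 to compound 3 (1.99 log units; beyond the scatter) are both large, whereas a 1.9-fold lower number from compound 1 to compound 2 (0.27 log units; within the scatter) stays within the scatter. Compound 4, `CC1(C)Cc2c(sc(NC(=O)C3(O)CC3)c2C(N)=O)C(C)(C)O1`, differs from compound 3 by 1-hydroxycyclopropyl in place of 5-oxopyrrolidin-3-yl on a carbonyl carbon. Compound 4 thus no longer carries the 5-oxopyrrolidin-3-yl group that compound 3 bears in both large steps; its 1-hydroxycyclopropyl group has not been measured on this core, so the size of the gain is uncertain. The step from compound 3 to compound 4 is expected to be an at least 25-fold lower number from compound 3 to compound 4 (1.39 log units; beyond the scatter), a lower number in this assay. Compound 4 is estimated at 400 nM, within 80 nM to 4000 nM.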

Compound 4, half-maximal effective concentration: 23 nM
The estimate for compound 4 lay 17-fold (1.24 log units) above the measured number, and the stated range ends above it.
By their numbers in this assay, from the lowest: compound 4; then compounds 2 and 1 (each within the scatter of the next). At a limit, above all of these: compound 3.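

Going by these compounds alone, on the carbonyl carbon whose other neighbour is the amide-type nitrogen, 1-hydroxycyclopropyl gives the lowest number so far in this assay, with a 4.4-fold lower number from compound 2 to compound 4 (0.64 log units; beyond the scatter) and an 8.3-fold lower number from compound 1 to compound 4 (0.92 log units; beyond the scatter). The earlier compounds had shown this position holding its number or losing it, whereas this change shows that it can go lower with a small carbon-only ring carrying a hydroxyl, as in an at least 430-fold lower number from compound 3 to compound 4 (2.63 log units; beyond the scatter). Compound 3 stands at a limit of the assay and not at a number: the limit of > 10000 nM in this assay, at which 1 of the 4 values shown sits.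

The compounds shown do not separate the share of the hydroxyl from that of the three-membered ring. Going by these compounds, whether an unsubstituted cyclopropyl, a 1-aminocyclopropyl or a 1-hydroxycyclobutyl would keep the number this low stays open.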